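The source may report more compounds than this note shows. Statements on the series, on what has been measured and on what is new or still open speak of the compounds shown alone.

Compound 3 `COc1ccc(S/C(=C/c2ccccc2OCc2ccccc2)C(=O)c2ccc(Cl)cc2)cc1` was examined in a functional assay on DU-145 cells (Homo sapiens) for inhibition, read by trypan blue exclusion, with a stated time of 96 h (on this read-out lower numbers stand for stronger inhibition of growth and higher numbers for weaker inhibition of growth), where compound 3 gives 1000 nM. This is level with compound 1 `O=C(/C(=C\c1ccccc1OCc1ccccc1)S(=O)(=O)c1ccc(Br)cc1)c1ccc(Cl)cc1`, which in this assay gives 1000 nM, and with compound 2 `Cc1ccc(CS(=O)(=O)/C(=C/c2ccccc2OCc2ccccc2)C(=O)c2ccc(Cl)cc2)cc1`, which in this assay gives 1000 nM; the steps of no change at the digits printed from compound 1 to compound 2 (within the scatter), no change at the digits printed from compound 1 to compound 3 (within the scatter) and no change at the digits printed from compound 2 to compound 3 (within the scatter) all stay within the scatter. Compound 4 `O=C(/C(=C\c1ccccc1OCc1ccccc1)Sc1ccc(F)cc1)c1ccc(Cl)cc1` differs from compound 3 by fluoro in place of methoxy on an aromatic carbon, so that the sulfur-bound group goes from (4-methoxyphenyl)sulfanyl to (4-fluorophenyl)sulfanyl. Within the data shown here, no measured step covers this exact exchange, yet every earlier variation of the sulfur-bound group left this assay unmoved, so no step beyond the scatter is expected here either. Compound 4 is therefore estimated at 1000 nM, within 500 nM to 2000 nM, which would be a step of no change at the digits printed from compound 3 to compound 4 (within the scatter).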

Compound 4, concentration for 50% growth inhibition: 1000 nM
Compound 4: the middle estimate sits on the measured number at the digits printed; low and high end bracket the measured number.
By their numbers in this assay, from the lowest: compounds 1, 2, 3 and 4 (each within the scatter of the next).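

Exchanging methoxy for fluoro on an aromatic carbon, para to a large group, is the first change shown on the substituent of this ring itself, and in this assay it gives no change at the digits printed from compound 3 to compound 4 (within the scatter). The (4-fluorophenyl)sulfanyl group also stands level with the two sulfonyl groups, with no change at the digits printed from compound 2 to compound 4 (within the scatter) and no change at the digits printed from compound 1 to compound 4 (within the scatter). No available evidence bears on this result. Going by these compounds, whether an amine or a carboxylic acid on this aromatic carbon would move the read-out remains open, as does the effect of any change to the rest of the shared core.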